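The compounds below may be only part of what the source reports. "The series", "measured", "known", "first", "only" and "open" are said of these compounds alone.

In a functional assay on the whole organism for inhibition, with Brassica rapa subsp. chinensis as the target, with a stated time of 3 days, tested at 100 ppm (on this read-out lower numbers stand for less inhibition of growth and higher numbers for more inhibition of growth at the one concentration tested), the three measured compounds gave:

compound 1 `COC(=O)/C=C/c1ccc(C(C)C)cc1`: 38%
compound 2 `CCCCCCCCNC(=O)/C=C/c1ccccc1`: 34%
compound 3 `CCCCCOC(=O)/C=C/c1ccc(C(C)C)cc1`: 29%

Compound 1 and compound 3 share one core and differ in a single place: butyl in place of hydrogen on a saturated chain carbon bound to an oxygen next to a carbonyl group. The step that this change made, a number 9 percentage points lower from compound 1 to compound 3 (within the scatter), lies within the scatter of the measurement, so the two numbers cannot be told apart. Compound 2 is built on a different core; the difference between the core of compound 1 and the core of compound 2 is not broken down here. Its value in this assay sits close to those of compound 1 and compound 3, all within the usual scatter of one another.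

Compound 4 `CCCCCCCCCCCCNC(=O)/C=C/c1ccccc1` has not yet been measured. It differs from compound 2 in one place: butyl in place of hydrogen on a saturated chain carbon, eight bonds along the chain from an amide-type nitrogen. Among the compounds with values here, this is the same kind of change as the one from compound 1 to compound 3, a butyl in place of a hydrogen on a saturated chain carbon, but not the same change: in compound 3 that carbon is bound to an oxygen next to a carbonyl group, whereas in compound 4 it lies eight bonds along the chain from an amide-type nitrogen. Within the data shown here, only one example of this kind of change has been measured. Because a number 9 percentage points lower from compound 1 to compound 3 (within the scatter) stayed within the scatter, a step of similar size is expected here too, a number 6 percentage points lower from compound 2 to compound 4 (within the scatter). On this basis compound 4 is expected to give about 28% in this assay, with a likely range from 12% to 45%.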

Compound 4, percent growth inhibition at one concentration: 48%
Compound 4: the middle estimate sits 20 percentage points below what was measured; measured number outside the range, above it.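

In this assay, putting butyl in place of hydrogen on a saturated chain carbon, eight bonds along the chain from an amide-type nitrogen, gave a number 14 percentage points higher from compound 2 to compound 4 (beyond the scatter), a step large enough to read as real. Set beside the earlier step, this shows that the change does not carry over from one core to the other as a fixed amount, so a step seen on one core is a poor guide to the step on the other: the same change on two cores in this assay, a number 9 percentage points lower (within the scatter) from compound 1 to compound 3 and a number 14 percentage points higher (beyond the scatter) from compound 2 to compound 4, 23 percentage points apart, beyond the scatter of two such steps. It does not show which feature of the two cores sets the steps apart or why they differ, and each core rests on a single pair of compounds, so no general rule for the series follows from them.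

The compounds shown leave open whether the rise on the core of compound 2 would continue with a longer chain than the one in compound 4, and whether a longer chain on the core of compound 1 would behave in the same way. They also leave open what an amine or a carboxylic acid in place of the butyl would do to growth inhibition on either core.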